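Adding a heptyl to a triazole-linked sphingolipid analogue

The source may report more compounds than this note shows. Statements on the series, on what has been measured and on what is new or still open speak of the compounds shown alone.

Four compounds share a triazole ring carried on a sugar-alcohol-like head group with a long fatty tail; they differ in the head group and in the chain attached to the ring. Compound 1 `CCCCCCCCCCCCCC[C@@H](O)[C@@H](O)[C@H](CO)n1cc(CCCCCC)nn1` and compound 3 `CCCCCCCCCCCCC/C=C/[C@@H](O)[C@H](CO)n1cc(CCCCCC)nn1` have different cores, and the difference between the two cores is not broken down here. In a functional assay on NCI-H358 cells (Homo sapiens) for cytotoxicity, read by sulforhodamine B assay (on this read-out higher numbers stand for an effect only at larger amounts of compound and lower numbers for an effect already at smaller amounts), compound 1 gives 13700 nM, and compound 3 gives 12800 nM, two numbers within the usual scatter of each other.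

Compound 2 `CCCCCCCCCCCCC/C=C/[C@@H](O)[C@H](CO)n1cc(CCCCCCCCCCCCC)nn1` differs from compound 3 by heptyl in place of hydrogen on a saturated chain carbon, six bonds along the chain from an aromatic carbon. In this assay compound 2 reaches only a limit, > 50000 nM, and no number. The change gives an at least 3.9-fold higher number from compound 3 to compound 2 (0.59 log units; beyond the scatter), a step that ends at the limit of > 50000 nM in this assay, at which 1 of the 3 values shown sits.

Within the data shown here, compound 4 `CCCCCCCCCCCCCC[C@@H](O)[C@@H](O)[C@H](CO)n1cc(CCCCCCCCCCCCC)nn1`, not yet measured, differs from compound 1 by heptyl in place of hydrogen on a saturated chain carbon, six bonds along the chain from an aromatic carbon, the same change as the one from compound 3 to compound 2, made on the other core. Since compound 1 and compound 3 sit so close together, the step is expected to repeat in similar size, so from compound 1 to compound 4 a step of a 4.0-fold higher number from compound 1 to compound 4 (0.60 log units; beyond the scatter) is estimated. Compound 4 is therefore expected to give about 55000 nM in this assay, with a real chance that only a limit is reported, as happened with compound 2.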

Compound 4, half-maximal effective concentration: > 50000 nM
Compound 4: no number, only a limit; the forecaster's own chance of this, stated with the estimate: 60%; the middle value is on the limit's open side.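

In this assay compound 4 reaches only a limit, > 50000 nM, and not a number. Putting heptyl in place of hydrogen at this place gives an at least 3.6-fold higher number from compound 1 to compound 4 (0.56 log units; beyond the scatter), so on both cores shown the same change moves the number upward by more than the usual scatter, and the two steps can be set side by side: the same change on two cores in this assay, an at least 3.9-fold higher number (0.59 log units; beyond the scatter) from compound 3 to compound 2 and an at least 3.6-fold higher number (0.56 log units; beyond the scatter) from compound 1 to compound 4; the limit leaves it open whether they differ. What this does not show is the true size of either step, or whether the change counts for more on one core than on the other, since both steps run into the same ceiling of the assay: the limit of > 50000 nM in this assay, at which 2 of the 4 values shown sit.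

The compounds shown leave open whether a smaller addition at the same place, such as a methyl or a propyl, would already raise the number, and so how far along this range of chain lengths the rise begins. They also leave open what a group of a different kind would do there, for example an amine or a carboxylic acid in place of the heptyl, on either core.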